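The source may hold more compounds than are shown below. What is called first, only, known or untested is meant among the compounds shown, and "the series" means these compounds.

The series shares one core, seen in compound 1 `COC(=O)c1sc2cc(Nc3cc(OC)cc(OC)c3)cnc2c1N`, compound 2 `COC(=O)c1sc2cc(Nc3cc(OC)ccc3Cl)cnc2c1N` and compound 3 `COC(=O)c1sc2cc(Nc3ccccc3Br)cnc2c1N`, and is followed in a functional assay on A375-C5 cells (Homo sapiens) for inhibition, read by sulforhodamine B assay, with a stated time of 48 h; a higher number here means a weaker inhibitor of growth, a lower number a stronger inhibitor of growth. Compound 1 reaches only the limit of the assay in this assay, recorded as > 150000 nM (the limit of > 150000 nM in this assay, at which 1 of the 3 values shown sits). Compound 2 gives 25800 nM in this assay. Compound 3 gives 34100 nM in this assay; its number and that of compound 2 lie within the scatter of one another, so the two cannot be told apart on these figures. Compound 4 `COC(=O)c1sc2cc(Nc3ccc(F)cc3Br)cnc2c1N` has not yet been measured. It differs from compound 3 by fluoro in place of hydrogen on an aromatic carbon. Going by the values given here, no measured pair in the set shows what such an exchange does, so the expectation rests on the small size of the change alone. The step of a 1.1-fold lower number from compound 3 to compound 4 (0.06 log units; within the scatter) is expected to stay within the scatter, in no particular direction. Compound 4 is therefore estimated at 30000 nM in this assay, with a likely range from 12000 nM to 75000 nM.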

Compound 4, concentration for 50% growth inhibition: 34000 nM
Compound 4: the middle estimate sits 1.1-fold (0.05 log units) below what was measured, within the range that was stated.
By their numbers in this assay, from the lowest: compounds 2, 4 and 3 (each within the scatter of the next). At a limit, above all of these: compound 1.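

In this assay the exchange at this position reads as a 1.0-fold lower number from compound 3 to compound 4 (0.00 log units; within the scatter), so compound 3 and compound 4 cannot be told apart on these figures. Going by these compounds alone, this is the only pair in the set that differs in one place, and it gives the first direct reading of a single change on the aromatic ring. At this carbon, meta to a bromo group and para to a large group, fluoro in place of hydrogen brings no difference that these numbers can show.

From the compounds shown here alone, it remains open whether an amine, a carboxylic acid or a trifluoromethyl group at this position would also stay within the scatter, or whether fluoro would behave the same way without the bromo group. Nothing measured here bears on why the exchange reads as it does.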